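The source may hold more compounds than are shown below. What is called first, only, known or untested is meant among the compounds shown, and "the series" means these compounds.

Working notes on the series, measured in a functional assay on PC-3 cells (Homo sapiens) for inhibition, read by sulforhodamine B assay, with a stated time of 48 h, tested at 50 uM; a higher number here means more inhibition of growth at the concentration tested, a lower number less inhibition of growth:

- compound 1 `COc1ccc([C@@H]2CC(=O)c3cc(CC=C(C)C)c(OC)cc3O2)cc1`: 58%
- compound 2 `COc1cc2c(cc1CC=C(C)C)C(=O)C[C@@H](c1ccc(Oc3ccc(F)cc3)cc1)O2`: 19%
- compound 3 `CCOc1ccc([C@@H]2CC(=O)c3cc(CC=C(C)C)c(OC)cc3O2)cc1`: 60%

Compound 3 gives 60% and sits level with compound 1 at 58%, as the step is a number 2 percentage points higher from compound 1 to compound 3 (within the scatter). Against compound 2 the picture differs, with a number 41 percentage points higher from compound 2 to compound 3 (beyond the scatter).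

The next member, compound 4 `C#CCOc1ccc([C@@H]2CC(=O)c3cc(CC=C(C)C)c(OC)cc3O2)cc1`, replaces the ethoxy of compound 3 with propargyloxy: ethynyl in place of methyl on a saturated chain carbon bound to an oxygen on an aromatic ring. In words, this is ethynyl in place of methyl on a saturated chain carbon bound to an oxygen on an aromatic ring.

Two kinds of measured step bear on this change. Extending the chain on the same oxygen, with methyl in place of hydrogen, gave a number 2 percentage points higher from compound 1 to compound 3 (within the scatter). Putting 4-fluorophenyl on that oxygen gave a number 39 percentage points lower from compound 1 to compound 2 (beyond the scatter). For the measured compounds named here, no ring enters in the new change, so it resembles the first kind more closely, though no compound with a triple bond has been measured yet and the evidence is thin. No step beyond the scatter is therefore expected, and the expected outcome is a number 3 percentage points lower from compound 3 to compound 4 (within the scatter). For compound 4 the estimated value is 57%, with an expected range of 42% to 72%.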

Compound 4, percent growth inhibition at one concentration: 52%
For compound 4 the middle estimate is 5 percentage points above the measured one, within the range that was stated.
By their numbers in this assay, from the lowest: compound 2; then compounds 4, 1 and 3 (each within the scatter of the next).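

In this assay, a triple bond on the saturated chain carbon bound to the oxygen on the aromatic ring leaves the read-out within the scatter, both for ethynyl in place of methyl (a number 8 percentage points lower from compound 3 to compound 4 (within the scatter)) and for ethynyl in place of hydrogen (a number 6 percentage points lower from compound 1 to compound 4 (within the scatter)), so compounds 1, 3 and 4 cannot be told apart and the methoxy, ethoxy and propargyloxy members stand at one level. Propargyl in place of 4-fluorophenyl (a number 33 percentage points higher from compound 2 to compound 4 (beyond the scatter)) gives a large step, so compound 2 remains apart from all three non-ring members, and the gap now holds for an unsaturated chain as well as for the saturated ones. No measurement accompanies these numbers that could explain the gap, so the series gives its size and no reason for it.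

Still open, going by these compounds, is whether a longer chain, an amine or a carboxylic acid on this oxygen would stay at the level of compounds 1, 3 and 4. Also open, on these data alone, is whether a plain phenyl or a benzyl group there would give a value close to that of compound 2 (19%) or stay with the non-ring members.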